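The compounds below may be only part of what the source reports. "The series", "measured", "known", "first", "only" and "open" are said of these compounds alone.

Compound 1 `N=C(N)c1ccc(-c2cc3cc(C(=N)N)ccc3o2)cc1`: 1900 nM
Compound 2 `COc1cc(C2=NCCN2)cc2cc(-c3ccc(C4=NCCN4)cc3)oc12`: 19900 nM
Compound 3 `N=C(N)c1ccc(-c2cc3cc(C(=N)N)cc(O)c3o2)cc1`: 184000 nM

In an ADME assay on L6 cells (Rattus norvegicus) for cytotoxicity (a higher number here means a weaker inhibitor, a lower number a stronger inhibitor), compound 1 gives 1900 nM, the lowest number of the three. Compound 4 `COc1cc(C(=N)N)ccc1-c1cc2cc(C(=N)N)ccc2o1` is compound 1 with methoxy in place of hydrogen on an aromatic carbon. For the measured compounds named here, the only measured single change is a hydroxy in place of hydrogen on an aromatic carbon, a 97-fold higher number from compound 1 to compound 3 (1.99 log units; beyond the scatter), a large step. Methoxy is a different group, and that step is only a loose guide. Compound 2 also carries a methoxy, but it differs from compound 1 in more than one place and offers no single-change comparison. The expected change is a 3.2-fold higher number from compound 1 to compound 4 (0.50 log units; beyond the scatter), a smaller move in the same direction. For compound 4 the estimated value is 6000 nM, with an expected range from 1500 nM to 40000 nM.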

Compound 4, half-maximal inhibitory concentration: 157000 nM
For compound 4 the middle estimate is 26-fold (1.42 log units) below the measured one; measured number outside the range, above it.
By their numbers in this assay, from the lowest: compound 1; then compound 2; then compounds 4 and 3 (each within the scatter of the next).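

In this assay, methoxy on this aromatic carbon, ortho to a large group, gives an 83-fold higher number from compound 1 to compound 4 (1.92 log units; beyond the scatter), so a group of only 2 heavy atoms at this place is enough for a large step. Together with a 97-fold higher number from compound 1 to compound 3 (1.99 log units; beyond the scatter), this makes two single changes to compound 1 that each raise the number by a large step. Nothing measured here explains the rise. As far as these compounds go, whether a methyl group, a fluorine atom or an amine on this same carbon would move the number as far remains open.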